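Acyl group on the ring nitrogen: a step to be repeated

A few compounds are considered here, and "the series" means these few. Any claim that something is new, unique, unknown or untested is made for them only; others in the source may bear on it.

Measured so far:
compound 1 `O=C(Nc1ccccc1C(F)(F)F)C1CCc2ccccc2N1`, 53300 nM
compound 2 `O=C(Nc1ccccc1C(F)(F)F)C1CCc2ccccc2N1C(=O)c1cccc(Cl)c1`, 729 nM
compound 3 `O=C(Nc1ccccc1O)C1CCc2ccccc2N1`, 4310 nM

The values come from a functional assay on PC-3 cells (Homo sapiens) for cytotoxicity, read by sulforhodamine B assay, with a stated time of 72 h; on this read-out higher numbers stand for weaker inhibition of growth and lower numbers for stronger inhibition of growth. The two cores differ as follows: hydroxy in place of trifluoromethyl on an aromatic carbon; this alone gave a 12-fold lower number from compound 1 to compound 3 (1.09 log units; beyond the scatter). The change that now matters is (3-chlorophenyl)carbonyl in place of hydrogen on a nitrogen on an aromatic ring in a ring; in the measured pair it gave a 73-fold lower number from compound 1 to compound 2 (1.86 log units; beyond the scatter). Compound 4 `O=C(Nc1ccccc1O)C1CCc2ccccc2N1C(=O)c1cccc(Cl)c1` carries the same change on the core of compound 3: (3-chlorophenyl)carbonyl in place of hydrogen on a nitrogen on an aromatic ring in a ring. Going by the values given here, because a 73-fold lower number from compound 1 to compound 2 (1.86 log units; beyond the scatter) was large, a step of similar direction and size is expected from compound 3 to compound 4, about a 54-fold lower number from compound 3 to compound 4 (1.73 log units; beyond the scatter), though with only one prior example its size is uncertain. Compound 4 is therefore estimated at 80 nM, most likely between 20 nM and 400 nM.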

Compound 4, concentration for 50% growth inhibition: 23300 nM
Compound 4: middle estimate off by 290-fold (2.46 log units), on the low side; measured number above the stated range.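

In this assay, putting (3-chlorophenyl)carbonyl on the nitrogen of the core of compound 3 gave a 5.4-fold higher number from compound 3 to compound 4 (0.73 log units; beyond the scatter), so the drop seen on the core of compound 1 did not carry over: the same change on two cores in this assay, a 73-fold lower number (1.86 log units; beyond the scatter) from compound 1 to compound 2 and a 5.4-fold higher number (0.73 log units; beyond the scatter) from compound 3 to compound 4, 400-fold (2.60 log units) apart, beyond the scatter of two such steps

Read the other way, hydroxy in place of trifluoromethyl gave a 32-fold higher number from compound 2 to compound 4 (1.50 log units; beyond the scatter) once the acyl group was present, the opposite direction to its effect without that group: the same change on two cores in this assay, a 12-fold lower number (1.09 log units; beyond the scatter) from compound 1 to compound 3 and a 32-fold higher number (1.50 log units; beyond the scatter) from compound 2 to compound 4, 400-fold (2.60 log units) apart, beyond the scatter of two such steps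

In these four compounds the outcome of each change thus depends on the other, but this does not show why, and two cores give no rule for any further core.

From the compounds shown here alone, it remains open whether a methoxy or an amine in place of hydroxy would follow compound 2 or compound 4. Going by these compounds, it also remains open whether an acetyl group on the nitrogen would show the same dependence on the core.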